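The source may report more compounds than this note shows. Statements on the series, on what has been measured and on what is new or still open speak of the compounds shown alone.

Measured compounds:
compound 1 `O=C(O)CCc1ccc2[nH]c(-c3ccccc3C(F)(F)F)cc2c1` – 1310 nM
compound 2 `CC(C)c1ccccc1-c1cc2cc(CCC(=O)O)ccc2[nH]1` – > 25 nM
compound 3 `COc1ccccc1-c1cc2cc(CCC(=O)O)ccc2[nH]1` – > 25 nM

Read-out throughout is a functional assay on CHO cells for agonist activity at Free fatty acid receptor 1 (Homo sapiens), read by a luciferase reporter, with a stated time of 24 h; on this read-out higher numbers stand for an effect only at larger amounts of compound and lower numbers for an effect already at smaller amounts. Compound 1 gives a number in this assay. For compound 3 the value is a limit of the assay, not a number. For compound 2 the value is likewise a limit. Compound 3 therefore stands at the limit, as noted by the limit of > 25 nM in this assay, at which 2 of the 3 values shown sit; where it lies relative to compound 1 cannot be read off.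

The step to compound 4 `O=C(O)CCc1ccc2[nH]c(-c3ccccc3Cl)cc2c1` is chloro in place of methoxy on an aromatic carbon. The measured steps that bear on it all involve the same position: a step that the limit leaves unreadable from compound 1 to compound 2, a step that the limit leaves unreadable from compound 1 to compound 3 and a step that the two limits leave unreadable from compound 2 to compound 3, none of them readable in size because of the limits. Among the compounds with values here, the only number available is that of compound 1 with trifluoromethyl at that position.

Compound 4 is expected to sit near compound 1, at an estimated 1000 nM (range 250 nM to 4000 nM), which implies an expected step that the limit leaves unreadable from compound 3 to compound 4 from the limit of compound 3; a further limit report is possible.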

Compound 4, half-maximal effective concentration: 54.6 nM
Compound 4: the middle estimate sits 18-fold (1.26 log units) above what was measured; the whole stated range lies above it.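

In this assay, within the data shown here, the change of chloro in place of trifluoromethyl gives a 24-fold lower number from compound 1 to compound 4 (1.38 log units; beyond the scatter) and is the first readable step at this aromatic carbon, ortho to a large group. The group at this one position can therefore shift the number beyond the scatter while the rest of the core of compound 1 stays the same. The steps that involve compound 2 or compound 3 cannot be read, so chloro cannot be placed relative to isopropyl or methoxy: the limit of > 25 nM in this assay, at which 2 of the 4 values shown sit.

Any trend across groups at this position rests on a single readable pair, compound 1 and compound 4, and so remains open. Also open, as far as these compounds go, is how an amine, a nitrile or a fluoro at the same aromatic carbon would read, and whether the step from trifluoromethyl to chloro holds on a core with a longer chain carrying the carboxylic acid.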